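A Methyl Step Repeated on a Second Core

This account rests on a few compounds, and the source may have more. Where it says the series, first, only, none or still open, it means among the compounds named here.

In a functional assay on MCF7 cells (Homo sapiens) for antiproliferative activity, read by MTT assay, with a stated time of 48 h (a lower number here means a stronger inhibitor, a higher number a weaker inhibitor), the three measured compounds stand as follows:
Compound 1 `O=C(NS(=O)(=O)c1ccccc1)c1cncc(Br)c1` gives 12900 nM.
Compound 2 `Cc1ccc(S(=O)(=O)NC(=O)c2cncc(Br)c2)cc1` gives 9370 nM.
Compound 3 `O=C(NS(=O)(=O)c1ccccc1)c1ccc(Cl)nc1` gives 14100 nM.

Compound 2 differs from compound 1 by methyl in place of hydrogen on an aromatic carbon, and that change made a 1.4-fold lower number from compound 1 to compound 2 (0.14 log units; within the scatter). Compound 3 carries a different core from compound 1; the difference between the two cores is not broken down here, and their two values lie within the scatter of each other. Compound 4 `Cc1ccc(S(=O)(=O)NC(=O)c2ccc(Cl)nc2)cc1` is not yet measured. It differs from compound 3 by methyl in place of hydrogen on an aromatic carbon, the same change as from compound 1 to compound 2. In this assay the step from compound 3 to compound 4 is expected to be a 1.3-fold lower number from compound 3 to compound 4 (0.13 log units; within the scatter), because a 1.4-fold lower number from compound 1 to compound 2 (0.14 log units; within the scatter) was within the scatter. Compound 4 is therefore estimated at 10500 nM, between 5500 nM and 20000 nM.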

Compound 4, half-maximal inhibitory concentration: 17200 nM
The estimate for compound 4 lay 1.6-fold (0.21 log units) below the measured number; the measured number falls inside the stated range.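

In this assay, methyl in place of hydrogen on an aromatic carbon gave a 1.2-fold higher number from compound 3 to compound 4 (0.09 log units; within the scatter). Set beside the earlier step, the change shows no difference between the two cores: the same change on two cores in this assay, a 1.4-fold lower number (0.14 log units; within the scatter) from compound 1 to compound 2 and a 1.2-fold higher number (0.09 log units; within the scatter) from compound 3 to compound 4, 1.7-fold (0.23 log units) apart, within the scatter of two such steps. Going by these compounds alone, this shows only that the step stayed within the scatter on both cores; it does not show a shared effect that carries from one core to the other, and the opposite directions of the two steps cannot be read as real.

The compounds shown leave open what a group other than methyl, such as a methoxy group, an amine or a carboxylic acid, would do at this place. Going by these compounds, whether any step large enough to stand beyond the scatter would carry between these cores also remains open.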